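Methoxy for Chloro on a Cyclopropyl Quinolone Core

The compounds below may be only part of what the source reports. "The series", "measured", "known", "first", "only" and "open" are said of these compounds alone.

Compound 1 `CCn1cc(-c2ccc(Cl)cc2)c(=O)c2cc(F)c(N3CCNCC3)cc21` was tested in a functional assay on HepG2 cells (Homo sapiens) for antiproliferative activity, read by MTT assay, with a stated time of 48 h (a higher number here means a weaker inhibitor, a lower number a stronger inhibitor), where compound 1 gives 24000 nM. Compound 2 `CCn1cc(-c2ccc(OC)cc2)c(=O)c2cc(F)c(N3CCNCC3)cc21` carries methoxy in place of chloro on an aromatic carbon; in this assay compound 2 gives 57900 nM, so that change produced a 2.4-fold higher number from compound 1 to compound 2 (0.38 log units; beyond the scatter). Compound 3 `O=c1c(-c2ccc(Cl)cc2)cn(C2CC2)c2cc(N3CCNCC3)c(F)cc12` differs from compound 1 by cyclopropyl in place of ethyl on an aromatic nitrogen, and in this assay compound 3 gives 8020 nM, a step of a 3.0-fold lower number from compound 1 to compound 3 (0.48 log units; beyond the scatter). Compound 4 `COc1ccc(-c2cn(C3CC3)c3cc(N4CCNCC4)c(F)cc3c2=O)cc1` has not yet been measured. It differs from compound 3 by methoxy in place of chloro on an aromatic carbon, the same change that separates compound 1 from compound 2, now set on the core of compound 3. Because the same change gave a 2.4-fold higher number from compound 1 to compound 2 (0.38 log units; beyond the scatter), a step of about that size is expected here, a 2.4-fold higher number from compound 3 to compound 4 (0.37 log units; beyond the scatter). Compound 4 is therefore estimated to give 19000 nM in this assay, most likely between 8000 nM and 45000 nM.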

Compound 4, half-maximal inhibitory concentration: 20800 nM
Estimate against measurement, compound 4: 1.1-fold (0.04 log units) below; the measured number falls inside the stated range.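

Methoxy in place of chloro gave a 2.6-fold higher number from compound 3 to compound 4 (0.41 log units; beyond the scatter) in this assay, and this step matches the one seen on the core of compound 1: the same change on two cores in this assay, a 2.4-fold higher number (0.38 log units; beyond the scatter) from compound 1 to compound 2 and a 2.6-fold higher number (0.41 log units; beyond the scatter) from compound 3 to compound 4, 1.1-fold (0.03 log units) apart, within the scatter of two such steps. Cyclopropyl in place of ethyl gave a 2.8-fold lower number from compound 2 to compound 4 (0.44 log units; beyond the scatter), and this change also carried over between the two cores: the same change on two cores in this assay, a 3.0-fold lower number (0.48 log units; beyond the scatter) from compound 1 to compound 3 and a 2.8-fold lower number (0.44 log units; beyond the scatter) from compound 2 to compound 4, 1.1-fold (0.03 log units) apart, within the scatter of two such steps. Both changes therefore kept their size across these four compounds, but this single set of two aromatic substituents and two nitrogen substituents does not show that they would do so on any other core or in any other assay.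

The compounds shown leave open how a hydroxyl or a nitrile in place of chloro would behave in this assay. They also leave open the effect of a longer chain, such as propyl, in place of ethyl on the aromatic nitrogen.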